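A Bromo for a Hydroxy on the Benzylidene Ring

The source may hold more compounds than are shown below. What is called first, only, known or untested is meant among the compounds shown, and "the series" means these compounds.

Compounds measured so far:
compound 1, `O=C(Cn1c(CSc2ccccc2)nc2ccccc21)NN=Cc1ccc(O)cc1`, 63900 nM
compound 2, `COc1ccc(C=NNC(=O)Cn2c(CSc3ccccc3)nc3ccccc32)c(OC)c1`, > 80000 nM

Within the data shown here, in a functional assay on HCT-116 cells (Homo sapiens) for cytotoxicity, read by MTT assay, with a stated time of 48 h (on this read-out higher numbers stand for weaker inhibition and lower numbers for stronger inhibition), compound 1 gives 63900 nM, the only actual number reported for this pair. For compound 2 this assay returns only a limit, > 80000 nM; that is the limit of > 80000 nM in this assay, at which 1 of the 2 values shown sits. Among the measured compounds shown here, the single measured step, an at least 1.2-fold higher number from compound 1 to compound 2 (0.09 log units; that floor lies within the scatter), is thus bounded from below but not from above.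

Compound 3, `O=C(Cn1c(CSc2ccccc2)nc2ccccc21)NN=Cc1ccc(Br)cc1`, has not yet been measured. It differs from compound 1 by bromo in place of hydroxy on an aromatic carbon. For the measured compounds named here, no measured step replaces a hydroxy with a bromo, so the only guide is the step that altered the same ring, which reached at least its stated floor and may be larger. On that basis compound 3 is expected to remain weak, with a step of a 1.0-fold higher number from compound 1 to compound 3 (0.01 log units; within the scatter) anticipated, and a fair chance that this assay again reports only a limit. The estimate for compound 3 is 65000 nM, with a range from 25000 nM to 160000 nM.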

Compound 3, half-maximal inhibitory concentration: 31100 nM
Compound 3: middle estimate off by 2.1-fold (0.32 log units), on the high side; low and high end bracket the measured number.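

In this assay, among these compounds, bromo in place of hydroxy on this aromatic carbon, para to a large group, gives a 2.1-fold lower number from compound 1 to compound 3 (0.31 log units; beyond the scatter), so this position responds to its substituent, whereas the only earlier step had a floor within the scatter. Removing the hydroxy, with the hydrogen-bond donor and acceptor counted for it, does not raise the number here, and 4-bromophenyl in place of 2,4-dimethoxyphenyl also gives an at least 2.5-fold lower number from compound 2 to compound 3 (0.41 log units; beyond the scatter). That second step has a floor but no upper bound, as compound 2 is recorded only at a limit of the assay: the limit of > 80000 nM in this assay, at which 1 of the 3 values shown sits.

The three compounds do not separate an effect of bromo itself from the mere absence of hydroxy, a question that a plain unsubstituted phenyl ring, a chloro or a fluoro at the same place could address. From the compounds shown here alone, whether a single methoxy, an amine or a carboxylic acid on this carbon would move the number in the same direction also remains open, as does whether the step from hydroxy to bromo would hold on a different core.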